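This account rests on a few compounds, and the source may have more. Where it says the series, first, only, none or still open, it means among the compounds named here.

Measured compounds:
compound 1, `COc1cc2c(cc1CC=C(C)C)C(=O)C[C@@H](c1ccc(Oc3ccccc3)cc1)O2` — 76%
compound 3, `COc1cc2c(cc1CCC(C)C)C(=O)C[C@@H](c1ccc(O)cc1)O2` — 77%
compound 2, `COc1ccc([C@@H]2C/C(=N/OCc3cn(-c4cccc(CO)c4)nn3)c3cc(CC=C(C)C)c(OC)cc3O2)cc1` — 27%

In a functional assay on HCT-116 cells (Homo sapiens) for inhibition, read by sulforhodamine B assay, with a stated time of 48 h, tested at 50 uM (on this read-out higher numbers stand for more inhibition of growth at the one concentration tested and lower numbers for less inhibition of growth), compound 1 gives 76% and compound 3 gives 77%; these two numbers lie within the scatter of each other and are not ordered. In this assay compound 2 gives 27%, the lowest of the three numbers. Its nearest neighbour is compound 1, a gap beyond the scatter; compound 3 stands further off, again beyond the scatter. Compound 2 is the only one of the three that carries the five-membered aromatic ring with 3 nitrogen and the group on its aromatic nitrogen.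

Compound 4, `COc1ccc([C@@H]2C/C(=N/OCc3cn(-c4cc(OC)c(OC)c(OC)c4)nn3)c3cc(CC=C(C)C)c(OC)cc3O2)cc1`, has not yet been measured in this assay. It differs from compound 2 in one place: 3,4,5-trimethoxyphenyl in place of 3-(hydroxymethyl)phenyl on an aromatic nitrogen. Among the compounds with values here, no pair of measured compounds differs in a single place, so no measured step shows what a change of this kind does here, and the direction cannot be read from the data. The group is exchanged at a position remote from the shared core, and the expectation is a step of a number 3 percentage points higher from compound 2 to compound 4 (within the scatter) of small size, not beyond the scatter, in either direction. Compound 4 is therefore expected to give about 30% in this assay, estimated within 10% to 55%.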

Compound 4, percent growth inhibition at one concentration: 29%
Estimate against measurement, compound 4: 1 percentage points above, within the range that was stated.
By their numbers in this assay, from the lowest: compounds 2 and 4 (each within the scatter of the next); then compounds 1 and 3 (each within the scatter of the next).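

In this assay, within the data shown here, placing 3,4,5-trimethoxyphenyl in place of 3-(hydroxymethyl)phenyl on an aromatic nitrogen of the five-membered aromatic ring with 3 nitrogen gives a number 2 percentage points higher from compound 2 to compound 4 (within the scatter), the first step that can be read at a single place. At this position, in this one pair, going from a group with 8 heavy atoms and 1 hydrogen-bond donor to one with 12 heavy atoms and 0 hydrogen-bond donors does not separate the two compounds beyond the scatter, so the hydroxymethyl group is not required for a number at this level. No measurement on hand speaks to the reason for this result.

As far as these compounds go, both groups in this pair are built on a six-membered aromatic ring of carbon only, so it remains open whether an amine, a carboxylic acid or a longer alkyl chain on the same aromatic nitrogen would give a step beyond the scatter. Compound 1 and compound 3 each differ from compound 2 and compound 4 in more than one place, so the gap between these two sets of numbers cannot be assigned to any single part of the structures.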